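Working notes on a one-carbon chain extension and cytotoxicity

The compounds below may be only part of what the source reports. "The series", "measured", "known", "first", "only" and "open" are said of these compounds alone.

Compound 1 `CC1=CC(=O)/C(=C(/C)Nc2ccc3cnn(C)c3c2)C(=O)O1` sits at a limit in an ADME assay on RAW264.7 cells (Mus musculus) for cytotoxicity, read by resazurin assay, with a stated time of 48 h; on this read-out lower numbers stand for higher toxicity in this test and higher numbers for lower toxicity in this test: compound 1 gives > 100000 nM, which is a limit and not a number. Compound 2 `CCn1ncc2ccc(N/C(C)=C3\C(=O)C=C(C)OC3=O)cc21` likewise reaches a limit; in this assay compound 2 gives > 100000 nM. The two differ by methyl in place of hydrogen on a saturated chain carbon bound to an aromatic nitrogen, and the step that the two limits leave unreadable from compound 1 to compound 2 cannot be read because both values are the limit of > 100000 nM in this assay, at which 2 of the 3 values shown sit. Among the compounds with values here, compound 3 `CC1=CC(=O)/C(=C(/C)Nc2ccc3c(Cl)n(C)nc3c2)C(=O)O1` carries a different core, and the difference between the two cores is not broken down here; in this assay compound 3 gives 6260 nM, the only number. Within the data shown here, compound 4 `CCn1nc2cc(N/C(C)=C3\C(=O)C=C(C)OC3=O)ccc2c1Cl` is reached from compound 3 by methyl in place of hydrogen on a saturated chain carbon bound to an aromatic nitrogen, the same change as the one between compound 1 and compound 2, at the same place. Among the measured compounds shown here, no measured pair gives a readable size for this change, so the expectation is a step within the usual scatter; the step expected is a 1.0-fold lower number from compound 3 to compound 4 (0.02 log units; within the scatter). For compound 4 the value expected in this assay is 6000 nM, with a range from 2000 nM to 20000 nM.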

Compound 4, half-maximal cytotoxic concentration: 6250 nM
The estimate for compound 4 lay 1.0-fold (0.02 log units) below the measured number; measured number inside the range.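

In this assay, the change of methyl in place of hydrogen on a saturated chain carbon bound to an aromatic nitrogen gives a 1.0-fold lower number from compound 3 to compound 4 (0.00 log units; within the scatter), so on the core of compound 3 the methyl to ethyl difference stays within the scatter. The same change on the core of compound 1 cannot be read, because both of its compounds stand at a limit and not at a number: the limit of > 100000 nM in this assay, at which 2 of the 4 values shown sit. This leaves a single readable pair, which shows the size of the change on one core only and does not show that this size carries over from one core to the other.

Open, going by these compounds, is whether a longer chain, such as propyl, would stay within the scatter on the core of compound 3 as ethyl does. Also open, on these data alone, is what a chain ending in an amine or a carboxylic acid, in the same place, would give on that core.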